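The source may report more compounds than this note shows. Statements on the series, on what has been measured and on what is new or still open speak of the compounds shown alone.

Compound 1 `COc1cc(NC(C)CCCNC(=O)Nc2ccc(F)cc2)c2ncccc2c1` gives 25000 nM in a functional assay on SW-620 cells (Homo sapiens) for inhibition, read by MTT assay, with a stated time of 72 h; on this read-out lower numbers stand for stronger inhibition and higher numbers for weaker inhibition. Compound 2 `COc1cc(NC(C)CCCNC(=O)NNC(=O)Nc2cccc(F)c2)c2ncccc2c1` gives 9500 nM in this assay, and compound 3 `COc1cc(NC(C)CCCNC(=O)Nc2ccc(C(F)(F)F)cc2)c2ncccc2c1` gives 22000 nM. The cores of compound 1 and compound 2 differ by ((3-fluorophenyl)carbamoyl)amino in place of 4-fluorophenyl on an amide-type nitrogen, which gives a 2.6-fold lower number from compound 1 to compound 2 (0.42 log units; beyond the scatter). Between compound 1 and compound 3 the change is trifluoromethyl in place of fluoro on an aromatic carbon, and it yields a 1.1-fold lower number from compound 1 to compound 3 (0.06 log units; within the scatter). The step of a 2.3-fold higher number from compound 2 to compound 3 (0.36 log units; beyond the scatter) is also recorded. Compound 4 `COc1cc(NC(C)CCCNC(=O)NNC(=O)Nc2cccc(C(F)(F)F)c2)c2ncccc2c1` is not yet measured; relative to compound 2 the change is trifluoromethyl in place of fluoro on an aromatic carbon. The places are not identical: in compound 3 the entering group sits para to a large group, in compound 4 meta to a large group, so this is the same kind of change rather than the same change. From compound 2 to compound 4 the expected step is a 1.1-fold lower number from compound 2 to compound 4 (0.05 log units; within the scatter), resting on the small step of a 1.1-fold lower number from compound 1 to compound 3 (0.06 log units; within the scatter) seen on the core of compound 1. Compound 4 is therefore estimated at 8500 nM, expected to fall between 3500 nM and 20000 nM.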

Compound 4, half-maximal inhibitory concentration: 21000 nM
Estimate against measurement, compound 4: 2.5-fold (0.39 log units) below, outside the stated range (above it).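

In this assay, trifluoromethyl in place of fluoro on the core of compound 2 gives a 2.2-fold higher number from compound 2 to compound 4 (0.34 log units; beyond the scatter). Set beside the earlier step, the change gives no firm sign of behaving differently on the two cores: the same change on two cores in this assay, a 1.1-fold lower number (0.06 log units; within the scatter) from compound 1 to compound 3 and a 2.2-fold higher number (0.34 log units; beyond the scatter) from compound 2 to compound 4, 2.5-fold (0.40 log units) apart, within the scatter of two such steps. Going by these compounds alone, this does not show that the change carries over unaltered: only two pairs stand here, with the entering group para to a large group in compound 3 and meta to a large group in compound 4, so core and place remain unseparated.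

Open, going by these compounds, is whether the step holds with the group at one place on both cores. Also open, on these data alone, is how a nitrile or a carboxylic acid on the same aromatic carbon would read in this assay.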